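The source may hold more compounds than are shown below. What is called first, only, known or untested is meant among the compounds shown, and "the series" means these compounds.

In an assay on HEK293 cells for positive allosteric modulation of metabotropic glutamate receptor 5 (Homo sapiens), read by FLIPR (a lower number here means that less compound is needed, a higher number that more compound is needed for the effect), compound 1 `O=C([C@H]1CC2CCC1C2)N1CC(c2nc(-c3cccc(F)c3)no2)C1` gives 72 nM, and compound 3 `CC1CCC(C(=O)N2CC(c3nc(-c4cccc(Cl)c4)no3)C2)CC1` gives 1500 nM, the higher of the two numbers reported and separated from compound 1 by a gap well beyond the usual scatter. Compound 2 `Cc1cccc(-c2noc(C3CN(S(=O)(=O)c4cccc(C)c4)C3)n2)c1` reaches only the limit of this assay, > 10000 nM (the limit of > 10000 nM in this assay, at which 1 of the 3 values shown sits). Compound 4 `O=C(C1CCC1)N1CC(c2nc(-c3cccc(Cl)c3)no2)C1` arises from compound 3 by a single change: cyclobutyl in place of 4-methylcyclohexyl on a carbonyl carbon. Within the data shown here, no step between two measured compounds isolates this change, so its effect is open. In this assay a modest move downward is expected, a 1.9-fold lower number from compound 3 to compound 4 (0.27 log units; within the scatter). Compound 4 is therefore estimated at 800 nM, with the likely range running from 200 nM to 4000 nM.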

Compound 4, half-maximal effective concentration: > 10000 nM
Compound 4: a limit, no number; the forecaster's own chance of this, stated with the estimate: 10%; middle value at least 12-fold (1.09 log units) away from the limit.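

In this assay, putting cyclobutyl in place of 4-methylcyclohexyl on the carbonyl carbon gives an at least 6.6-fold higher number from compound 3 to compound 4 (0.82 log units; beyond the scatter). Among these compounds, this is the first readable step at this position, and it shows that activity here depends strongly on which carbon ring is attached. Compound 4 stands at a limit of the assay, not at a number: the limit of > 10000 nM in this assay, at which 2 of the 4 values shown sit.

On these data alone, the full size of the step therefore stays unknown. Also open, as far as these compounds go, is how cyclopentyl, an open chain such as isobutyl, or a cyclohexyl ring carrying an amine would behave on this carbonyl carbon.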